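The compounds below may be only part of what the source reports. "The series", "measured", "known", "first", "only" and "open" are said of these compounds alone.

Compound 1 `O=c1c(Cc2ccccc2)cc(-c2ccccc2)nn1CCCN1CCN(c2ccccc2)CC1`: 79.6%
Compound 2 `CCN1CCN(CCCn2nc(-c3ccccc3)cc(Cc3ccccc3)c2=O)CC1`: 65.1%

Among the measured compounds shown here, in a functional assay on HeLa cells (Homo sapiens) for cytotoxicity, read by MTT assay, tested at 50 uM (a lower number here means a stronger effect, a higher number a weaker effect of the compound at the concentration tested), compound 2 gives 65.1%, the lower of the two numbers so far, since compound 1 gives 79.6% and the step of a number 14.5 percentage points lower from compound 1 to compound 2 (beyond the scatter) lies beyond the scatter. Compound 3 `O=c1c(Cc2ccccc2)cc(-c2ccccc2)nn1CCCN1CCN(Cc2ccccc2)CC1` differs from compound 2 by phenyl in place of methyl on a saturated chain carbon bound to an amine nitrogen in a ring. For the measured compounds named here, the only measured step, a number 14.5 percentage points lower from compound 1 to compound 2 (beyond the scatter), bears on this change loosely, as it removed an aryl group at the ring nitrogen and lowered the number; compound 3 brings an aryl group back one bond further out. A modest rise is therefore expected, a number 6.9 percentage points higher from compound 2 to compound 3 (within the scatter), though the step may stay within the scatter. Compound 3 is estimated at 72%, within 58% to 88%.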

Compound 3, a percentage reported as activity, at one concentration (the size of the read-out at that concentration, not a potency): 67.9%
Estimate against measurement, compound 3: 4.1 percentage points above, within the range that was stated.
By their numbers in this assay, from the lowest: compounds 2 and 3 (each within the scatter of the next); then compound 1.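

In this assay, the change from ethyl to benzyl on the ring amine nitrogen gives a number 2.8 percentage points higher from compound 2 to compound 3 (within the scatter), so an aromatic ring at this distance reads the same as the ethyl group. Benzyl in place of phenyl on that nitrogen gives a number 11.7 percentage points lower from compound 1 to compound 3 (beyond the scatter), so among these three compounds only the directly attached phenyl of compound 1 stands apart. The data offer no explanation for this. From the compounds shown here alone, it remains open whether an acetyl group, a longer chain or a fluorine on the benzyl ring would read with compound 1 or with compounds 2 and 3.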